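Swapping the hydroxyphenyl of compound 3 for a methoxy-hydroxy ring

The compounds below may be only part of what the source reports. "The series", "measured", "known", "first", "only" and "open" are said of these compounds alone.

Compound 3 `O=C(/C=C/c1cccc(O)c1)c1cccc(-n2cc(-c3ccc(Cl)cc3)[nH]c2=O)c1` is measured in a functional assay on NCI-H460 cells (Homo sapiens) for inhibition (on this read-out higher numbers stand for weaker inhibition of growth and lower numbers for stronger inhibition of growth), where it gives 2410 nM. That is the lowest of the three numbers, yet it sits within the scatter of compound 2 `O=C(/C=C/c1cccc(O)c1)c1cccc(-n2cc(-c3ccccc3)[nH]c2=O)c1` at 2490 nM and of compound 1 `COc1cc(/C=C/C(=O)c2cccc(-n3cc(-c4ccc(Cl)cc4)[nH]c3=O)c2)cc(OC)c1OC` at 3740 nM. Among the measured compounds shown here, the one measured step, a 1.0-fold lower number from compound 2 to compound 3 (0.01 log units; within the scatter), concerns a different part of the molecule. Compound 4 `COc1cc(/C=C/C(=O)c2cccc(-n3cc(-c4ccc(Cl)cc4)[nH]c3=O)c2)ccc1O` differs from compound 3 by 4-hydroxy-3-methoxyphenyl in place of 3-hydroxyphenyl on a double-bonded chain carbon bound to a double-bonded chain carbon. For the measured compounds named here, no measured step matches this change; compound 1 and compound 3, which differ at the same ring, show numbers within the scatter of each other. On that basis the expected step of a 1.2-fold higher number from compound 3 to compound 4 (0.07 log units; within the scatter) stays within the scatter. Compound 4 is therefore estimated at 2800 nM, with a range from 1200 nM to 6500 nM.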

Compound 4, concentration for 50% growth inhibition: 3900 nM
Compound 4: the middle estimate sits 1.4-fold (0.14 log units) below what was measured; the measured number falls inside the stated range.
By their numbers in this assay, from the lowest: compounds 3, 2, 1 and 4 (each within the scatter of the next).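

Among the compounds shown here, putting 4-hydroxy-3-methoxyphenyl at this position gives a 1.6-fold higher number from compound 3 to compound 4 (0.21 log units; within the scatter) in this assay, the first direct reading of a change to this ring alone. The ring can therefore carry the extra carbon and oxygen of the entering group without a shift beyond the scatter. Nothing available gives a reason for this result. As far as these compounds go, whether a ring bearing an amine or a carboxylic acid would behave the same way stays open. So does whether any replacement at this position can move the number beyond the scatter.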